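A few compounds are considered here, and "the series" means these few. Any claim that something is new, unique, unknown or untested is made for them only; others in the source may bear on it.

The series shares one core bearing a hydroxycyclohexyl group on the double-bonded nitrogen. Compound 1, `Cn1nc(-c2ccc(C(N)=O)cc2)s/c1=N\C1CCCC(O)C1`, was run twice in an in vivo ADME assay on the whole organism for pharmacokinetics, at a dose of 2.5 mg/kg by the oral route (on this read-out higher numbers stand for a longer-lived compound and lower numbers for a shorter-lived compound), and gave 1.42 h; 1.8 h (2 entries); the two readings of compound 1 agree within the usual scatter (the several entries of compound 1 in this assay, 1.42 h; 1.8 h (2 entries)). Compound 3, `CC(=O)Nc1ccc(-c2nn(C)/c(=N/C3CCCC(O)C3)s2)cc1`, gives 2.3 h in this assay. Compound 2, `Cn1nc(-c2ccc(C(N)=O)cc2)s/c1=N\C1CCC(O)CC1`, gives 0.27 h in this assay, the lowest of the two single numbers; its nearest neighbour, compound 3, stands higher by a gap beyond the scatter, while compound 1 contributes a pair of entries rather than one number, both of them well above compound 2.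

Compound 4, `Cn1nc(-c2ccc(C(N)=O)cc2)s/c1=N\C1CCCCC1O`, has not yet been measured. It differs from compound 2 only by 2-hydroxycyclohexyl in place of 4-hydroxycyclohexyl on a double-bonded nitrogen. Within the data shown here, no pair of measured compounds differing in one place is available, so the size of this move in this assay can only be guessed from the spread between compound 2 and its neighbours. The step in this assay is expected to be a moderate increase, a 3.0-fold higher number from compound 2 to compound 4 (0.47 log units; beyond the scatter), which would lie at the edge of the scatter. Compound 4 is therefore estimated to give a half-life of 0.8 h, with a range from 0.25 h to 2.5 h.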

Compound 4, half-life: 0.31 h
Compound 4: middle estimate off by 2.6-fold (0.41 log units), on the high side; the measured number falls inside the stated range.
By their numbers in this assay, from the lowest: compounds 2 and 4 (each within the scatter of the next); then compound 3.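

Putting 2-hydroxycyclohexyl in place of 4-hydroxycyclohexyl on a double-bonded nitrogen gives a 1.1-fold higher number from compound 2 to compound 4 (0.06 log units; within the scatter) in this assay. Among these compounds, this is the only comparison in the set for which a step can be read, and it shows that these two groups, with the same atoms joined differently, leave compound 2 and compound 4 level on half-life. Among the compounds shown here, compound 1, which also carries a hydroxycyclohexyl group at this place, gives 1.42 h; 1.8 h (2 entries), entries that stand above the printed numbers of the other two, although no step to it can be read, so the hydroxycyclohexyl groups tried here do not all read alike.

Nothing in the data bears on why these groups stand as they do. As far as these compounds go, what remains open is whether an amine or a methoxy group in place of the hydroxyl on the cyclohexyl ring would read like compound 2 and compound 4, and whether 2-hydroxycyclohexyl would read the same way on the core of compound 3.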